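Replacing the Nitrophenyl Sulfonyl with a Dichlorophenyl Sulfonyl

The source may report more compounds than this note shows. Statements on the series, on what has been measured and on what is new or still open speak of the compounds shown alone.

In a functional assay on Jurkat cells (Homo sapiens) for antiproliferative activity, read by MTT assay and trypan blue exclusion, with a stated time of 72 h (on this read-out higher numbers stand for weaker inhibition and lower numbers for stronger inhibition), compound 3 `COC(=O)c1ccc(C2SCC(=O)N2c2ccc(N3CCN(S(=O)(=O)c4ccc([N+](=O)[O-])cc4)CC3)cn2)c(OC)c1` gives 54000 nM, the highest of the two numbers shown. Compound 1 `COC(=O)c1ccc(C2SCC(=O)N2c2ccc(N3CCN(S(=O)(=O)c4ccccc4)CC3)cn2)c(OC)c1` gives 52900 nM in this assay, and the change of a 1.0-fold higher number from compound 1 to compound 3 (0.01 log units; within the scatter) separates them. Compound 2 `COC(=O)c1ccc(C2SCC(=O)N2c2ccc(N3CCN(Cc4cccc(C)c4)CC3)cn2)c(OC)c1` gives > 100000 nM in this assay, which is a limit and not a number, as the limit of > 100000 nM in this assay, at which 1 of the 3 values shown sits, states.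

Compound 4 `COC(=O)c1ccc(C2SCC(=O)N2c2ccc(N3CCN(S(=O)(=O)c4cc(Cl)ccc4Cl)CC3)cn2)c(OC)c1` departs from compound 3 by 2,5-dichlorophenyl in place of 4-nitrophenyl on a sulfonyl sulfur. The steps measured so far, an at least 1.8-fold higher number from compound 1 to compound 2 (0.27 log units; that floor lies within the scatter) and an at least 1.8-fold lower number from compound 2 to compound 3 (0.26 log units; that floor lies within the scatter), both sit within the scatter, and none involves a dichlorophenyl. It is therefore expected that the step of a 1.1-fold lower number from compound 3 to compound 4 (0.03 log units; within the scatter) stays within the scatter. Compound 4 is estimated at 50000 nM, ranging from 20000 nM to 100000 nM.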

Compound 4, half-maximal inhibitory concentration: > 100000 nM
Compound 4: a limit, no number; the forecaster's own chance of this, stated with the estimate: 30%; middle value at least 2.0-fold (0.30 log units) away from the limit.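

In this assay, compound 4 gives a limit and not a number, and it is the second compound to do so: the limit of > 100000 nM in this assay, at which 2 of the 4 values shown sit. Among the sulfonyl compounds shown, only compound 4 sits at this limit, so the group on the sulfonyl sulfur can separate a measured number from a limit, with an at least 1.8-fold higher number from compound 3 to compound 4 (0.26 log units; that floor lies within the scatter) and an at least 1.8-fold higher number from compound 1 to compound 4 (0.27 log units; that floor lies within the scatter). The step between compound 2 and compound 4 cannot be read. The compounds shown leave open whether a single chlorine on that phenyl, or a methoxy or an amine there, would give a measured number.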